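Bromo in Place of Fluoro on the Pendant Aryl Ring

The compounds below may be only part of what the source reports. "The series", "measured", "known", "first", "only" and "open" are said of these compounds alone.

Of the compounds shown here, three sharing one core have been measured in an assay on isolated protein for agonist activity at Bile acid receptor (Homo sapiens), read by AlphaScreen, with a stated time of 30 min; a lower number here means a smaller maximal response, a higher number a larger maximal response. Compound 1 `Cc1nn(-c2ccccc2I)c2c1C(c1ccc(Oc3ccccc3)cc1)SC(C)C(=O)N2` gives 130%. Compound 2 `Cc1nn(-c2ccccc2Cl)c2c1C(c1ccc(Oc3ccccc3)cc1)SC(C)C(=O)N2` gives 57%, and compound 3 `Cc1nn(-c2ccccc2F)c2c1C(c1ccc(Oc3ccccc3)cc1)SC(C)C(=O)N2` gives 72%. On these numbers compound 3 stands second highest of the three: the step of a number 15 percentage points higher from compound 2 to compound 3 (beyond the scatter) is modest, while the step of a number 58 percentage points lower from compound 1 to compound 3 (beyond the scatter) is large.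

Compound 4 `Cc1nn(-c2ccccc2Br)c2c1C(c1ccc(Oc3ccccc3)cc1)SC(C)C(=O)N2` differs from compound 3 in one place: bromo in place of fluoro on an aromatic carbon. Every measured step in this set is a swap of one halogen for another at the same carbon, so all three bear on this change. The steps of a number 73 percentage points lower from compound 1 to compound 2 (beyond the scatter) and a number 58 percentage points lower from compound 1 to compound 3 (beyond the scatter) are large, and the step of a number 15 percentage points higher from compound 2 to compound 3 (beyond the scatter) is modest. The three halogens do not order the response in a single direction, so the bromo compound cannot simply be read off a trend; its nearest measured neighbours in the series give the bounds. Compound 4 is expected to show a step of a number 18 percentage points higher from compound 3 to compound 4 (beyond the scatter) in this assay, upward but uncertain in size. Compound 4 is therefore estimated at 90%, within a range from 60% to 130%.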

Compound 4, largest response reached (reported as efficacy), in percent of the reference or control that the assay uses: 84%
For compound 4 the middle estimate is 6 percentage points above the measured one; measured number inside the range.
By their numbers in this assay, from the lowest: compound 2; then compound 3; then compound 4; then compound 1.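

In this assay, for the compounds shown here, bromo takes a place among the halogens at this carbon that the earlier compounds could not fix, with a step of a number 12 percentage points higher from compound 3 to compound 4 (beyond the scatter), a step of a number 27 percentage points higher from compound 2 to compound 4 (beyond the scatter), and a step of a number 46 percentage points lower from compound 1 to compound 4 (beyond the scatter). The response now rises in the order chloro, bromo, iodo, with compound 3 going against that order by standing above compound 2, and the largest of the new steps is the one that separates bromo from iodo, so the high response of compound 1 belongs to iodo alone among these four halogens. Nothing available explains why the halogens fall in this order at this carbon.

The compounds shown leave open whether any group other than a halogen, such as a methyl, a methoxy or a nitrile, could match or pass iodo on this ring. They also leave open whether this order holds for anything beyond the maximal response, since a single read-out describes all four compounds.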